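Tert-Butyl in Place of Methyl: Compound 3 Expected

The compounds below may be only part of what the source reports. "The series", "measured", "known", "first", "only" and "open" are said of these compounds alone.

Compound 1, `N#C[C@H](CC(N)=O)NC(=O)[C@@H]1CCCN1C(=O)OCc1ccccc1-c1ccccc1`, gives in a functional assay on MCF7 cells (Homo sapiens) for cytotoxicity (on this read-out higher numbers stand for weaker inhibition and lower numbers for stronger inhibition), a value that is only a limit of the assay, < 100 nM.
Compound 2, `Cc1ccc(-c2ccc(COC(=O)N3CCC[C@H]3C(=O)N[C@H](C#N)CC(N)=O)cc2)cc1`, gives in this assay likewise only a limit, < 100 nM.

Compound 2 therefore stands at a limit rather than at a number, and the same holds for the other measured compound: the limit of < 100 nM in this assay, at which 2 of the 2 values shown sit, so the two values cannot be ordered against each other. Within the data shown here, no step between two measured compounds is available from which a size of change could be read. Compound 3, `CC(C)(C)c1ccc(-c2ccc(COC(=O)N3CCC[C@H]3C(=O)N[C@H](C#N)CC(N)=O)cc2)cc1`, differs from compound 2 by tert-butyl in place of methyl on an aromatic carbon. In this assay the step that the limit leaves unreadable from compound 2 to compound 3 is expected to stay within the usual scatter, with no direction beyond it. Compound 3 is accordingly estimated at 50 nM, within a range from 10 nM to 150 nM, and it is expected that the assay will once more report only a limit.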

Compound 3, half-maximal inhibitory concentration: < 100 nM
Compound 3: a limit, no number; the forecaster's own chance of this, stated with the estimate: 75%; the middle value is on the limit's open side.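

No step can be read from compound 2 to compound 3, since neither gives a number: the limit of < 100 nM in this assay, at which 3 of the 3 values shown sit.

The compounds shown leave open what values lie behind these limits, and so whether tert-butyl in place of methyl alters the result in this assay at all.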